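Thiosemicarbazones of the shared core: 2-chlorophenyl step

A few compounds are considered here, and "the series" means these few. Any claim that something is new, unique, unknown or untested is made for them only; others in the source may bear on it.

The series keeps the core of compound 1 `CC1=CC[C@@H]([C@@](C)(O)CCCC(C)(C)NC(=S)NN)CC1` and varies the group on the carbon with a double bond to nitrogen. In a functional assay on OVCAR-3 cells (Homo sapiens) for cytotoxicity, read by sulforhodamine B assay (on this read-out lower numbers stand for stronger inhibition of growth and higher numbers for weaker inhibition of growth), compound 1 gives > 100000 nM, which is a limit of the assay and not a number. Compound 2 `CC1=CC[C@@H]([C@@](C)(O)CCCC(C)(C)NC(=S)N/N=C\c2ccccc2[N+](=O)[O-])CC1` gives 16200 nM. Compound 3 `CC1=CC[C@@H]([C@@](C)(O)CCCC(C)(C)NC(=S)N/N=C\c2ccc([N+](=O)[O-])cc2)CC1` gives 88600 nM, the highest of the two numbers shown; its nearest neighbour is compound 2, the gap being a 5.5-fold higher number from compound 2 to compound 3 (0.74 log units; beyond the scatter).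

Compound 4 `CC1=CC[C@@H]([C@@](C)(O)CCCC(C)(C)NC(=S)N/N=C\c2ccccc2Cl)CC1` differs from compound 3 by 2-chlorophenyl in place of 4-nitrophenyl on a carbon with a double bond to nitrogen. For the measured compounds named here, the only measured step that bears on this change is the move between a 2-substituted and a 4-substituted phenyl, a 5.5-fold higher number from compound 2 to compound 3 (0.74 log units; beyond the scatter); no measured step compares a chloro with a nitro group, so that part of the change is untested here. A return to a 2-substituted phenyl is therefore expected to bring the number back towards that of compound 2, with added uncertainty for the chlorine. The step from compound 3 to compound 4 is expected to be a 3.5-fold lower number from compound 3 to compound 4 (0.55 log units; beyond the scatter). Compound 4 is estimated at 25000 nM, within 8000 nM to 80000 nM.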

Compound 4, concentration for total growth inhibition: > 100000 nM
Compound 4 gave a limit, no number; the forecaster's own chance of this, stated with the estimate: 10%; at least 4.0-fold (0.60 log units) between middle value and limit.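

Chloro in place of nitro on an aromatic carbon gives an at least 6.1-fold higher number from compound 2 to compound 4 (0.79 log units; beyond the scatter) in this assay, so the number seen with 2-nitrophenyl does not carry over to 2-chlorophenyl, and the group itself counts at this position, not only where it sits on the phenyl. Against 4-nitrophenyl, the change gives an at least 1.1-fold higher number from compound 3 to compound 4 (0.05 log units; that floor lies within the scatter); that floor lies within the scatter, so it does not separate the two compounds. Compound 4 stands at a limit of the assay and not at a number: the limit of > 100000 nM in this assay, at which 2 of the 4 values shown sit.

The step from compound 1 to compound 4 cannot be read, with both ends being limits. Going by these compounds, how far compound 4 lies past its limit stays open, as does whether an amine or a carboxylic acid in place of the chloro would bring the number back towards that of compound 2.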